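This account rests on a few compounds, and the source may have more. Where it says the series, first, only, none or still open, it means among the compounds named here.

Measured compounds:
Compound 1, `O=c1oc(Nc2ccccc2I)nc2ccccc12`: 3500 nM
Compound 2, `O=c1oc(Nc2ccccc2I)nc2cccc(Cl)c12`: 14500 nM

Both numbers come from an assay on isolated protein for inhibition of complement C1r subcomponent (Homo sapiens); a lower number here means a stronger inhibitor, a higher number a weaker inhibitor. Among the compounds with values here, of the two, compound 1 stands lower, and compound 2 is its only neighbour, reached by a 4.1-fold higher number from compound 1 to compound 2 (0.62 log units; beyond the scatter). That single step, a chloro in place of hydrogen on an aromatic carbon, is all that has been measured on this core so far.

Compound 3, `CC(C)c1ccc2c(=O)oc(Nc3ccccc3I)nc2c1`, is the next compound. It differs from compound 1 by isopropyl in place of hydrogen on an aromatic carbon. Within the data shown here, the one measured step bears on it only loosely: it concerns a different group at a different place on the shared core, and it brought a modest loss of potency that lay beyond the scatter. Among the measured compounds shown here, no step with an isopropyl, and none at the place in question, has yet been measured. The expectation therefore leans on the observation that the one substitution tried on this ring made the number higher, so a shift of similar or smaller size in the same direction is expected, while a result within the scatter of compound 1 would not be surprising. The expected step is a 1.6-fold higher number from compound 1 to compound 3 (0.20 log units; within the scatter). Compound 3 is estimated at 5500 nM in this assay, with a range from 1800 nM to 20000 nM.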

Compound 3, half-maximal inhibitory concentration: > 62500 nM
Compound 3: a limit, no number; the forecaster's own chance of this, stated with the estimate: 10%; middle value at least 11-fold (1.05 log units) from the limit.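

For compound 3, the result in this assay is a limit of the assay, not a number: the limit of > 62500 nM in this assay, at which 1 of the 3 values shown sits.
Even so, isopropyl in place of hydrogen on this aromatic carbon, meta to a fused ring and para to a fused ring, gives an at least 17-fold higher number from compound 1 to compound 3 (1.25 log units; beyond the scatter), so this change costs far more than the modest chloro step seen earlier, which gave a 4.1-fold higher number from compound 1 to compound 2 (0.62 log units; beyond the scatter). Both changes tried on this ring of the shared core raise the number, and neither compound goes against that, which shows that this place is not free to take a group in place of hydrogen without loss, at least in the case of isopropyl.

The compounds shown cannot say whether the loss belongs to isopropyl itself or to any group at this place, since chloro and isopropyl sit at different places on the core. A methyl, a methoxy or an amine at this same place would help separate the two, and chloro here would link this step directly to the earlier one.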